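A few compounds are considered here, and "the series" means these few. Any claim that something is new, unique, unknown or untested is made for them only; others in the source may bear on it.

Compound 1 `CCCCOc1ccc(-c2c(C)[nH]c(=O)n2C)cc1` gives 5100 nM in a functional assay on brain (Rattus norvegicus, strain Wistar) for inhibition; a higher number here means a weaker inhibitor, a lower number a stronger inhibitor.
Compound 2 `CCCCOc1ccc(-c2c(C)[nH]c(=O)n2C2CCCCC2)cc1` gives 13900 nM in this assay.

Compound 1 stands lowest of the two numbers in this assay; the step of a 2.7-fold higher number from compound 1 to compound 2 (0.44 log units; beyond the scatter) is a modest rise. Compound 3 `Cc1[nH]c(=O)n(C)c1-c1ccc(OC(C)C)cc1` differs from compound 1 at the oxygen on the aromatic ring: isopropyl in place of butyl on an oxygen on an aromatic ring. Within the data shown here, the only measured step, from compound 1 to compound 2, changes the group on an aromatic nitrogen, so no measured step bears on this butoxy to isopropoxy change. Without a guiding step, no change beyond the scatter is expected. Compound 3 is estimated at 6000 nM, between 2500 nM and 15000 nM, an expected step of a 1.2-fold higher number from compound 1 to compound 3 (0.07 log units; within the scatter).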

Compound 3, half-maximal inhibitory concentration: 20400 nM
For compound 3 the middle estimate is 3.4-fold (0.53 log units) below the measured one; the measured number lies above the stated range.
By their numbers in this assay, from the lowest: compound 1; then compounds 2 and 3 (each within the scatter of the next).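

Going from butoxy to isopropoxy gives a 4.0-fold higher number from compound 1 to compound 3 (0.60 log units; beyond the scatter) in this assay, so the group on this oxygen affects the number, just as the group on the aromatic nitrogen does. Of the two groups seen on this oxygen, butyl gives the stronger inhibitor. Nothing available explains this rise.

From the compounds shown here alone, whether a longer chain such as hexyl, or a chain ending in an amine or a carboxylic acid, would lower the number further stays open. So does whether this step would be the same size with cyclohexyl on the aromatic nitrogen.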